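Urea variation on a quinazoline-type core: a cyclic amine step

The source may report more compounds than this note shows. Statements on the series, on what has been measured and on what is new or still open speak of the compounds shown alone.

Compound 1 `COCCNC(=O)Nc1cc2c(Nc3ccc(F)c(Cl)c3)ncnc2cc1O[C@H]1CCOC1`: 387 nM
Compound 2 `COC(CCNC(=O)Nc1cc2c(Nc3ccc(F)c(Cl)c3)ncnc2cc1O[C@H]1CCOC1)OC`: 22000 nM
Compound 3 `CN1CCN(C(=O)Nc2cc3c(Nc4ccc(F)c(Cl)c4)ncnc3cc2O[C@H]2CCOC2)CC1`: 675 nM

The three measured compounds share one core and differ only in the group attached to the urea carbonyl carbon. In a functional assay on A-431 cells (Homo sapiens) for antiproliferative activity, read by sulforhodamine B assay, with a stated time of 72 h (a higher number here means a weaker inhibitor, a lower number a stronger inhibitor), compound 1 gives the lowest of the three numbers. Its nearest neighbour is compound 3, reached by a 1.7-fold higher number from compound 1 to compound 3 (0.24 log units; within the scatter), a step that does not separate the two. Its furthest neighbour is compound 2, reached by a 57-fold higher number from compound 1 to compound 2 (1.75 log units; beyond the scatter).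

Compound 4 `O=C(Nc1cc2c(Nc3ccc(F)c(Cl)c3)ncnc2cc1O[C@H]1CCOC1)N1CCC(F)(F)CC1` has not yet been measured in this assay. It differs from compound 1 in one place: 4,4-difluoropiperidin-1-yl in place of (2-methoxyethyl)amino on a carbonyl carbon. For the measured compounds named here, the step that bears most directly on this change is the one from compound 1 to compound 3, in which another six-membered amine ring replaced the (2-methoxyethyl)amino group on the same carbonyl carbon; that step stayed within the scatter. The step to compound 2, by contrast, altered the chain rather than closing a ring and so speaks less to this change. Compound 4 is therefore expected to sit close to compound 1, with a 1.6-fold higher number from compound 1 to compound 4 (0.19 log units; within the scatter) estimated to lie within the scatter. The estimated value of compound 4 in this assay is 600 nM, within a range from 200 nM to 2500 nM.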

Compound 4, half-maximal inhibitory concentration: 1860 nM
Beside the measured number, compound 4's estimate is 3.1-fold (0.49 log units) below it; measured number inside the range.
By their numbers in this assay, from the lowest: compounds 1 and 3 (each within the scatter of the next); then compound 4; then compound 2.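

In this assay a six-membered amine ring on the carbonyl carbon can no longer be treated as interchangeable with the open chain: 4,4-difluoropiperidin-1-yl gives a 4.8-fold higher number from compound 1 to compound 4 (0.68 log units; beyond the scatter) and so a modest loss beyond the scatter. The choice of ring matters as well, as replacing 4-methylpiperazin-1-yl with 4,4-difluoropiperidin-1-yl gives a 2.8-fold higher number from compound 3 to compound 4 (0.44 log units; beyond the scatter) and again a modest step. The same ring still fares much better than (3,3-dimethoxypropyl)amino, with a 12-fold lower number from compound 2 to compound 4 (1.07 log units; beyond the scatter) as a large step in the opposite direction. No accompanying measurement explains any of these steps.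

The compounds shown leave open where an unsubstituted piperidin-1-yl or a morpholin-4-yl group would fall on this carbonyl carbon. They also leave open whether a 4-methylpiperidin-1-yl group would stay with compound 3 or move towards compound 4.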